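This account rests on a few compounds, and the source may have more. Where it says the series, first, only, none or still open, it means among the compounds named here.

In a functional assay on MCF7 cells (Homo sapiens) for cytotoxicity, read by MTT assay, with a stated time of 72 h (a higher number here means a weaker inhibitor, a lower number a stronger inhibitor), compound 1 (`CCC(C)=C1C(=O)N(c2ccc(Cl)cc2)N(c2ccc(Cl)cc2)C1=O`) gives 41600 nM and compound 2 (`COc1cccc(C=C2C(=O)N(c3ccc(Cl)cc3)N(c3ccc(Cl)cc3)C2=O)c1`) gives 18100 nM as its result, so compound 1 holds the higher number of the two and is the weaker inhibitor. Compound 3 (`CC(=C1C(=O)N(c2ccc(Cl)cc2)N(c2ccc(Cl)cc2)C1=O)c1ccc(O)cc1`) has not yet been measured. It keeps the core of compound 1 but carries 4-hydroxyphenyl in place of ethyl on a double-bonded chain carbon bound to a double-bonded ring carbon and a saturated chain carbon. Among the compounds with values here, no measured pair shows this change alone, so any forecast is loose. Within the data shown here, the only guide is compound 2, whose 18100 nM sits lower than the number for compound 1, so a modest fall rather than a large one is expected in this assay for this change. The expected step of a 2.4-fold lower number from compound 1 to compound 3 (0.39 log units; beyond the scatter) is small and points toward a stronger inhibitor. For compound 3 the estimated value is 17000 nM with an expected range from 6000 nM to 45000 nM in this measurement.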

Compound 3, half-maximal inhibitory concentration: 76500 nM
The estimate for compound 3 lay 4.5-fold (0.65 log units) below the measured number; the measured number lies above the stated range.
By their numbers in this assay, from the lowest: compound 2; then compounds 1 and 3 (each within the scatter of the next).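

Within the data shown here, compound 1 and compound 3 form the first pair here that differs in one place, and putting 4-hydroxyphenyl in place of ethyl on this double-bonded chain carbon gives a 1.8-fold higher number from compound 1 to compound 3 (0.26 log units; within the scatter) in this assay. This position therefore accepts a much larger group carrying an aromatic ring and a hydroxyl without a change in the number that can be told from the scatter. Nothing measured here explains this outcome.

The change brings in the ring and the hydroxyl together, so the compounds shown cannot separate what each contributes. Still open, going by these compounds, is whether plain phenyl, a longer chain, or a phenyl ring carrying an amine or a carboxylic acid in place of the hydroxyl would move the number beyond the scatter.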